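Chalcone maleimides: chloro, methoxy, and now nitro

This account rests on a few compounds, and the source may have more. Where it says the series, first, only, none or still open, it means among the compounds named here.

Measured so far in a functional assay on MOLT-4 cells (Homo sapiens) for cytotoxicity; a higher number here means a weaker inhibitor, a lower number a stronger inhibitor:
compound 1, `O=C(/C=C/c1ccc(Cl)cc1)c1ccc(N2C(=O)C=CC2=O)cc1`, 7500 nM
compound 2, `COc1ccc(/C=C/C(=O)c2ccc(N3C(=O)C=CC3=O)cc2)cc1`, 7900 nM

Compound 2 gives the highest of the two numbers in this assay, yet its nearest neighbour is compound 1, and the step of a 1.1-fold higher number from compound 1 to compound 2 (0.02 log units; within the scatter) lies within the scatter, so the two compounds cannot be ordered.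

The next compound is compound 3, `O=C(/C=C/c1ccc([N+](=O)[O-])cc1)c1ccc(N2C(=O)C=CC2=O)cc1`. It differs from compound 2 in one place: nitro in place of methoxy on an aromatic carbon. Within the data shown here, the only measured step that bears on this position is a 1.1-fold higher number from compound 1 to compound 2 (0.02 log units; within the scatter), which shows that exchanging one small substituent for another at this carbon left the number essentially unchanged. On that basis the step of a 1.1-fold lower number from compound 2 to compound 3 (0.02 log units; within the scatter) is expected to stay within the scatter as well, with no direction to call. Compound 3 is therefore estimated at 7500 nM in this assay, within a range of 3500 nM to 16000 nM.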

Compound 3, half-maximal inhibitory concentration: > 500000 nM
Compound 3 was reported as a limit; the forecaster's own chance of this, stated with the estimate: 5%; middle value at least 66-fold (1.82 log units) from the limit.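

In this assay, nitro in place of methoxy gives an at least 63-fold higher number from compound 2 to compound 3 (1.80 log units; beyond the scatter), and nitro in place of chloro gives an at least 66-fold higher number from compound 1 to compound 3 (1.82 log units; beyond the scatter). Compound 1 and compound 2 could not be told apart, so the earlier pair gave no sign that this aromatic carbon responds to its substituent, whereas nitro now separates compound 3 from both of them, showing that the group here can matter a great deal. The value of compound 3 is a limit of the assay and not a number: the limit of > 500000 nM in this assay, at which 1 of the 3 values shown sits.

The three compounds leave open whether this large step belongs to nitro alone or would also appear with an amine, a carboxylic acid or a nitrile on the same carbon. They also leave open how a longer chain such as ethoxy or butoxy in place of methoxy would compare.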